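The compounds below may be only part of what the source reports. "The series", "measured", "known", "first", "only" and "open" are said of these compounds alone.

Two compounds have been measured in a functional assay on the whole organism (Peritoneal cavity) with Rattus norvegicus as the target; a lower number here means that less compound is needed, a higher number that more compound is needed for the effect:

compound 1 `CC(C)c1ccc2c(c1)c(SC(C)(C)C)c(CC(C)(C)CNC(N)=O)n2Cc1ccc(Cl)cc1`: 11 umol/kg
compound 2 `CC(C)(C)Sc1c(CC(C)(C)C(=O)O)n(Cc2ccc(Cl)cc2)c2ccc(OCc3cccc(Cl)n3)cc12`: 1.2 umol/kg

Compound 1 stands at the top of this short scale, so more of it is needed for the effect. The gap down to compound 2 lies beyond the usual scatter. The next compound to be tested is compound 3 `CC(C)c1ccc2c(c1)c(SC(C)(C)C)c(CC(C)(C)/C=N/OCC(=O)O)n2Cc1ccc(Cl)cc1`, which keeps the core of compound 1 and changes one group. Ureidomethyl leaves, and a group without a ring enters on a saturated chain carbon bound to three saturated chain carbons: a group of 7 heavy atoms (3 carbon, 1 nitrogen, 3 oxygen; no ring) in place of a group of 5 heavy atoms (2 carbon, 2 nitrogen, 1 oxygen; no ring), on a saturated chain carbon bound to three saturated chain carbons.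

Among the compounds with values here, no pair of measured compounds differs in one place, so no measurement shows what a single change does in this assay. The only guide is that compound 2 reaches 1.2 umol/kg, which shows that a much lower number is attainable among these compounds. A moderate fall in the number is therefore expected, probably just beyond the scatter, and the expected step is a 3.1-fold lower number from compound 1 to compound 3 (0.50 log units; beyond the scatter). For compound 3 the estimated value is 3.5 umol/kg, with an expected range from 1 umol/kg to 12 umol/kg.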

Compound 3, dose for half-maximal effect: 3 umol/kg
For compound 3 the middle estimate is 1.2-fold (0.07 log units) above the measured one; measured number inside the range.
By their numbers in this assay, from the lowest: compound 2; then compound 3; then compound 1.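

In this assay, the saturated chain carbon bound to three saturated chain carbons proves sensitive to what it carries: replacing ureidomethyl with the new group brings a 3.7-fold lower number from compound 1 to compound 3 (0.56 log units; beyond the scatter). As the first single-place step among these compounds, it shows that this position accepts a group of 7 heavy atoms in place of one of 5 heavy atoms with no rise in the number. The step is modest, and the two groups differ at once in size, in their atoms, in their double bonds and in their counts of hydrogen-bond donors and acceptors, while no independent measurement is available to explain the change or tie it to any one of these differences.

Within the data shown here, with only one step, it remains open which part of the incoming group goes with the lower number, and whether an amine, a methyl ester or a longer chain in the same place would give a similar result. As far as these compounds go, it also remains open whether the same exchange would give a step of similar size on the core of compound 2.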